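Swapping 2,4-dihydroxyphenyl for 4-fluorophenyl on a shared core

This account rests on a few compounds, and the source may have more. Where it says the series, first, only, none or still open, it means among the compounds named here.

Of the compounds shown here, three sharing one core have been tested in a functional assay on HeLa cells (Homo sapiens) for inhibition, read by MTT assay, with a stated time of 72 h; a lower number here means a stronger inhibitor, a higher number a weaker inhibitor. Compound 1 `COc1cc(OC)c(OC)cc1/C=C/C(=O)c1ccc(Cl)cc1` gives 36500 nM, compound 2 `COc1cc(OC)c(OC)cc1/C=C/C(=O)c1cc(OC(C)=O)ccc1OC(C)=O` gives 57900 nM, and compound 3 `COc1cc(OC)c(OC)cc1/C=C/C(=O)c1ccc(O)cc1O` gives 37600 nM. Compound 3 therefore lies within the usual scatter of each of the other two, so its number stands among theirs without being set apart from either.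

The next compound to consider is compound 4 `COc1cc(OC)c(OC)cc1/C=C/C(=O)c1ccc(F)cc1`. On the carbonyl carbon, it carries 4-fluorophenyl in place of 2,4-dihydroxyphenyl on a carbonyl carbon.

For the measured compounds named here, one measured step bears on this change. Compound 1 carries 4-chlorophenyl at that same carbonyl carbon, and replacing it with 2,4-dihydroxyphenyl gave a 1.0-fold higher number from compound 1 to compound 3 (0.01 log units; within the scatter), a step within the scatter. Going to compound 4 runs the same kind of swap the other way, ending on 4-fluorophenyl rather than 4-chlorophenyl. Going by the values given here, no compound with 4-fluorophenyl has been measured yet, so this expectation rests on that single step.

No shift beyond the scatter is therefore expected in this assay, and the estimated step is a 1.1-fold higher number from compound 3 to compound 4 (0.03 log units; within the scatter). For compound 4 the expected value is 40000 nM, with an estimated range from 20000 nM to 80000 nM.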

Compound 4, half-maximal inhibitory concentration: 28600 nM
Estimate against measurement, compound 4: 1.4-fold (0.15 log units) above; the range from low to high includes it.
By their numbers in this assay, from the lowest: compounds 4, 1, 3 and 2 (each within the scatter of the next, the first and the last beyond it).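

Replacing the 2,4-dihydroxyphenyl group with 4-fluorophenyl in this assay gives a 1.3-fold lower number from compound 3 to compound 4 (0.12 log units; within the scatter) even though the leaving group has hydrogen-bond donors and acceptors and the entering group has neither, so losing both at this carbonyl carbon does not separate the two compounds in this assay. For the compounds shown here, the first direct comparison of the two halogens, fluoro in place of chloro on an aromatic carbon, gives a 1.3-fold lower number from compound 1 to compound 4 (0.11 log units; within the scatter) and so does not separate that pair either. Going by these compounds alone, these results show only that the three groups cannot be told apart here, and no supporting measurement is available to explain why the number moves so little.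

Every group shown at this carbonyl carbon is a substituted phenyl ring, so it remains open whether an amine, a carboxylic acid or a longer chain on that ring would shift the number beyond the scatter. As far as these compounds go, it is equally open whether a change elsewhere on the shared core would matter more than these swaps have.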